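The compounds below may be only part of what the source reports. "The series", "measured", "known", "first", "only" and "open" are said of these compounds alone.

Within the data shown here, compound 1 `Nc1nc([SeH])nc2ncccc12` is the only member of this small series with a number: in a functional assay on CCRF-CEM cells (Homo sapiens) for cytotoxicity, read by MTT assay, with a stated time of 72 h (a lower number here means that less compound is tolerated, a higher number that more compound is tolerated), compound 1 gives 92100 nM, so it is tolerated up to a high concentration. Compound 2 `[SeH]c1nc([SeH])c2cccnc2n1` belongs to the same set, but in this assay compound 2 has "not determined" (no result reported), so no result is reported for it. Compound 3 `C[Se]c1nc(N)c2cccnc2n1` differs from compound 1 by methyl in place of hydrogen on a selenium. Among the measured compounds shown here, with no comparable step between measured compounds available, the change is expected to stay close to the usual scatter, leaning toward slightly more compound being tolerated, so that the step from compound 1 to compound 3 is estimated as a 1.3-fold higher number from compound 1 to compound 3 (0.11 log units; within the scatter). Compound 3 is therefore expected to give about 120000 nM, within 40000 nM to 350000 nM.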

Compound 3, concentration lethal to 50% of the cells: > 100000 nM
Compound 3: only a limit was reported (the forecaster's own chance of this, stated with the estimate: 30%); the middle value does not contradict the limit.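

Methyl in place of hydrogen on a selenium gives an at least 1.0-fold higher number from compound 1 to compound 3 (0.03 log units; that floor lies within the scatter) in this assay. Among these compounds, this first step at this position gives no sign that less compound is tolerated once the methyl is present, which compound 1 alone could not show. For compound 3 the result is a limit and not a number, so the step is only a floor: the limit of > 100000 nM in this assay, at which 1 of the 3 values shown sits.

The compounds shown leave open whether a longer chain or a carboxylic acid on this selenium would give the same picture. They also leave open how far the number actually rises with methyl.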